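Amide aryl variation on the shared core

The compounds below may be only part of what the source reports. "The series", "measured", "known", "first", "only" and "open" are said of these compounds alone.

Measured so far:
compound 1 `Cc1ccc(NC(=O)COc2ccc3cc(/C=C4/SC(=O)NC4=O)ccc3c2)cc1` — in an assay on isolated protein for inhibition of histone deacetylase 4 (Homo sapiens), with a stated time of 1 h (a lower number here means a stronger inhibitor, a higher number a weaker inhibitor), compound 1 gives 1700 nM
compound 2 `Cc1cc(Br)ccc1NC(=O)COc1ccc2cc(/C=C3/SC(=O)NC3=O)ccc2c1` — compound 2 gives 550 nM
compound 3 `O=C(COc1ccc2cc(/C=C3/SC(=O)NC3=O)ccc2c1)Nc1ccc([N+](=O)[O-])cc1` — compound 3 gives 1700 nM

Compound 3 stands level with compound 1 at the digits shown, the two together the highest numbers of the three; compound 2 is the furthest from it, a 3.1-fold higher number from compound 2 to compound 3 (0.49 log units; beyond the scatter). The next compound, compound 4 `COc1ccc(NC(=O)COc2ccc3cc(/C=C4/SC(=O)NC4=O)ccc3c2)cc1`, differs from compound 3 in one place: methoxy in place of nitro on an aromatic carbon.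

Going by the values given here, two measured steps bear on this. The closest comparison is no change at the digits printed from compound 1 to compound 3 (within the scatter): exchanging the group on this aromatic carbon left the number unchanged. Among the compounds with values here, the only step beyond the scatter, a 3.1-fold lower number from compound 1 to compound 2 (0.49 log units; beyond the scatter), involved a broader change of the amide aryl group rather than a single group on that carbon. A further exchange on the same aromatic carbon is therefore expected to give no step beyond the scatter in this assay, a 1.1-fold lower number from compound 3 to compound 4 (0.03 log units; within the scatter).

Compound 4 is estimated at 1600 nM, with a range of 700 nM to 3600 nM.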

Compound 4, half-maximal inhibitory concentration: 4700 nM
Estimate against measurement, compound 4: 2.9-fold (0.47 log units) below; measured number above the stated range.
By their numbers in this assay, from the lowest: compound 2; then compounds 1 and 3 (each within the scatter of the next); then compound 4.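

At this aromatic carbon, para to a large group, the exchange is not neutral in this assay: methyl and nitro left the number unchanged, but methoxy gives a 2.8-fold higher number from compound 1 to compound 4 (0.44 log units; beyond the scatter), and against nitro a 2.8-fold higher number from compound 3 to compound 4 (0.44 log units; beyond the scatter), so the flat result of the first exchange does not extend to every group. Compound 4 now has the highest number of the four, and the change from the 4-bromo-2-methylphenyl amide to the 4-methoxyphenyl amide gives an 8.5-fold higher number from compound 2 to compound 4 (0.93 log units; beyond the scatter), the widest step in the set. Nothing available explains why methoxy departs from methyl and nitro here.

From the compounds shown here alone, whether an amine, a chlorine or a carboxylic acid on this carbon would sit with methoxy or with methyl and nitro stays open. Also open, going by these compounds, is whether the bromine or the added methyl accounts for the lower number of compound 2.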